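Fluoro in place of the triazole on compound 3

The source may report more compounds than this note shows. Statements on the series, on what has been measured and on what is new or still open speak of the compounds shown alone.

Of the compounds shown here, three have been measured in an ADME assay on microsomes from liver (Homo sapiens) for metabolic stability, read by LC-MS, using NADPH, with a stated time of 10 min, tested at 0.1 uM; a higher number here means faster removal of the compound, a lower number slower removal. Compound 1 (`CC1SC(c2cccc(C(=O)NCCCCc3ccccc3)c2)N(c2ccc(C3CC3)cc2)C1=O`) gives 2010 mL.min-1.g-1, compound 2 (`Cc1ccnc(N2C(=O)CSC2c2cccc(C(=O)NCCCCn3cccn3)c2)c1`) gives 129 mL.min-1.g-1, and compound 3 (`O=C(NCCCCc1ccccc1)c1cccc(C2SCC(=O)N2c2cccc(-c3c[nH]nn3)c2)c1`) gives 261 mL.min-1.g-1. Compound 3 therefore stands in the middle of the three numbers, nearer to compound 2 than to compound 1, with both gaps beyond the scatter.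

Compound 4 (`O=C(NCCCCc1ccccc1)c1cccc(C2SCC(=O)N2c2cccc(F)c2)c1`) departs from compound 3 in one place: fluoro in place of 1H-1,2,3-triazol-4-yl on an aromatic carbon, with fluoro in place of 1H-1,2,3-triazol-4-yl on an aromatic carbon. Among the compounds with values here, no measured pair shows this change, so the expectation rests on indirect evidence. Sharing the amide side chain of compound 3 but lacking the 1H-1,2,3-triazol-4-yl group, compound 1 gives 2010 mL.min-1.g-1, which suggests faster removal without that group. However, compound 1 differs from compound 3 in more than one place. Compound 2 goes against this reading: it also lacks the group, yet gives 129 mL.min-1.g-1, although its amide side chain is different.

A moderate rise beyond the scatter is therefore expected in this assay. The expected change is a 2.7-fold higher number from compound 3 to compound 4 (0.43 log units; beyond the scatter). Compound 4 is estimated at 700 mL.min-1.g-1, with an expected range of 280 mL.min-1.g-1 to 1700 mL.min-1.g-1.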

Compound 4, intrinsic clearance in microsomes: 1840 mL.min-1.g-1
The estimate for compound 4 lay 2.6-fold (0.42 log units) below the measured number, outside the stated range (above it).
By their numbers in this assay, from the lowest: compound 2; then compound 3; then compounds 4 and 1 (each within the scatter of the next).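

In this assay, fluoro in place of 1H-1,2,3-triazol-4-yl on an aromatic carbon, meta to a large group, gives a 7.0-fold higher number from compound 3 to compound 4 (0.85 log units; beyond the scatter) with nothing else in the structure altered. Within the data shown here, this pair is the first direct reading of the change, as the earlier compounds offered only comparisons that differed in more than one place, and it shows that this one position alone can move removal by a step well beyond the scatter, with the triazole-bearing compound 3 the more slowly removed of the two. Nothing measured on these compounds accounts for the size of the step.

On these data alone, the pair does not separate the departure of the triazole from the arrival of fluoro, so it remains open whether hydrogen, a methoxy group, an amine, a carboxylic acid or a tetrazole at this position would stay near compound 3 or near compound 4. Among these compounds, also open is whether the same change gives a step of similar size when the amide side chain is the one carried by compound 2.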